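Swapping the arylamino substituent: compound 3 to compound 4

A few compounds are considered here, and "the series" means these few. Any claim that something is new, unique, unknown or untested is made for them only; others in the source may bear on it.

Compound 1 `FC(F)(F)c1ccc(CSc2nc(Nc3ccccc3)c3ccccc3n2)cc1` in a functional assay on HGC-27 cells (Homo sapiens) for cytotoxicity, read by MTT assay, with a stated time of 72 h (on this read-out higher numbers stand for weaker inhibition and lower numbers for stronger inhibition), gives 26400 nM. Compound 2 `COc1ccccc1Nc1nc(SCc2ccc(C(F)(F)F)cc2)nc2ccccc12` gives only a limit of the assay, > 50000 nM. Compound 3 `FC(F)(F)c1ccc(CSc2nc(Nc3cccc(C(F)(F)F)c3)c3ccccc3n2)cc1` gives 11700 nM and so stands lowest of the two numbers available, with compound 1 nearest: a 2.3-fold lower number from compound 1 to compound 3 (0.35 log units; beyond the scatter), and an at least 4.2-fold lower number from compound 2 to compound 3 (0.63 log units; beyond the scatter). Compound 4 `O=[N+]([O-])c1ccc(Nc2nc(SCc3ccc(C(F)(F)F)cc3)nc3ccccc23)cc1` is not yet measured. Its difference from compound 3 is 4-nitrophenyl in place of 3-(trifluoromethyl)phenyl on a nitrogen on an aromatic ring. For the measured compounds named here, two measured steps touch this part of the molecule. Going by the values given here, the step of a 2.3-fold lower number from compound 1 to compound 3 (0.35 log units; beyond the scatter) shows what trifluoromethyl on that ring brought, and the step of an at least 4.2-fold lower number from compound 2 to compound 3 (0.63 log units; beyond the scatter) shows that a different substituted phenyl on the same nitrogen gave a higher number; no measured compound carries a nitro group, so that part of the change has no precedent here. Removing the trifluoromethyl is expected to undo the modest gain, and the estimate for compound 4 is 22000 nM, with a range from 8000 nM to 50000 nM, as a step of a 1.9-fold higher number from compound 3 to compound 4 (0.27 log units; within the scatter) that is expected to be modest at most.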

Compound 4, half-maximal inhibitory concentration: 16600 nM
For compound 4 the middle estimate is 1.3-fold (0.12 log units) above the measured one, and the stated range covers the measured number.
By their numbers in this assay, from the lowest: compounds 3, 4 and 1 (each within the scatter of the next, the first and the last beyond it). At a limit, above all of these: compound 2.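

Swapping the substituted phenyl on the nitrogen leaves the read-out in this assay unresolved: a 1.4-fold higher number from compound 3 to compound 4 (0.15 log units; within the scatter), so 4-nitrophenyl and 3-(trifluoromethyl)phenyl cannot be told apart at this position. Compound 3 stood clear of the unsubstituted phenyl of compound 1, whereas the nitro change does not, with a 1.6-fold lower number from compound 1 to compound 4 (0.20 log units; within the scatter). The remaining step, an at least 3.0-fold lower number from compound 2 to compound 4 (0.47 log units; beyond the scatter), places 4-nitrophenyl clear of 2-methoxyphenyl, but it is only a floor, since its starting point is a limit: the limit of > 50000 nM in this assay, at which 1 of the 4 values shown sits.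

Going by these compounds, compound 3 and compound 4 differ in both the group and its place on the phenyl ring, so the contribution of each stays open. Also open, on these data alone, is how an amine or a carboxylic acid on that phenyl ring, or a longer chain on the nitrogen in place of the phenyl, would read.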